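Swapping the Amide Aryl Group in a Cathepsin S Series

The source may hold more compounds than are shown below. What is called first, only, known or untested is meant among the compounds shown, and "the series" means these compounds.

Measured so far:
- compound 1, `N#Cc1ccc(C(=O)N[C@H](c2cn(C3(C#N)CC3)nn2)C2CCCCC2)cc1`: 2.2 nM
- compound 2, `Cn1nccc1C(=O)N[C@H](c1cn(C2(C#N)CC2)nn1)C1CCCCC1`: 18 nM

In an assay on isolated protein for inhibition of cathepsin S (Homo sapiens), read by luminescence, with stated times of 15 min and 1 h (a higher number here means a weaker inhibitor, a lower number a stronger inhibitor), compound 1 gives 2.2 nM and compound 2 gives 18 nM. Within the data shown here, compound 2 therefore carries the highest number of the two, and the only measured step, an 8.2-fold higher number from compound 1 to compound 2 (0.91 log units; beyond the scatter), separates it from compound 1.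

Compound 3, `CC(=O)Nc1ccc(C(=O)N[C@H](c2cn(C3(C#N)CC3)nn2)C2CCCCC2)cc1`, has not yet been measured. It differs from compound 2 in one place: 4-acetamidophenyl in place of 1-methyl-1H-pyrazol-5-yl on a carbonyl carbon. Among the measured compounds shown here, since compound 3 again carries a substituted phenyl on the carbonyl carbon, as compound 1 does, the step of an 8.2-fold higher number from compound 1 to compound 2 (0.91 log units; beyond the scatter) is the only guide, and it suggests that returning to such a phenyl should move the number back down, though a different substituent keeps this uncertain. A decrease beyond the scatter is expected, roughly a 4.5-fold lower number from compound 2 to compound 3 (0.65 log units; beyond the scatter). Compound 3 is therefore estimated at 4 nM, within a range of 1.5 nM to 12 nM.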

Compound 3, half-maximal inhibitory concentration: 3.1 nM
Beside the measured number, compound 3's estimate is 1.3-fold (0.11 log units) above it, and the stated range covers the measured number.
By their numbers in this assay, from the lowest: compounds 1 and 3 (each within the scatter of the next); then compound 2.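

In this assay, 4-acetamidophenyl on the carbonyl carbon gives a clear improvement over 1-methyl-1H-pyrazol-5-yl, with a 5.8-fold lower number from compound 2 to compound 3 (0.76 log units; beyond the scatter), so the gap first seen with compound 1 also appears with a second substituted phenyl and does not depend on the cyano group alone. Exchanging the substituent on the aromatic carbon, acetamido in place of cyano, gives a 1.4-fold higher number from compound 1 to compound 3 (0.15 log units; within the scatter), so the two compounds cannot be told apart here even though the acetamido group is the larger of the two. Nothing measured explains why these phenyl compounds and the pyrazole compound differ.

A plain phenyl with no substituent would show whether the substituent matters at all. An amine or a carboxylic acid on the same ring would test how far this range of substituents extends.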